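The source may hold more compounds than are shown below. What is called first, only, known or untested is meant among the compounds shown, and "the series" means these compounds.

Compound 1 `S=C(Sc1ccccc1)N1CCCCC1`: 7930 nM
Compound 2 `CC(C)(C)OC(=O)N1CCN(C(=S)Sc2ccc(F)cc2)CC1`: 1560 nM

Among the measured compounds shown here, in a functional assay on A549 cells (Homo sapiens) for antiproliferative activity, read by MTT assay, with a stated time of 72 h (on this read-out higher numbers stand for weaker inhibition and lower numbers for stronger inhibition), compound 2 gives 1560 nM, the lower of the two numbers so far, and compound 1 gives 7930 nM. The gap between these two numbers lies beyond the scatter. For the measured compounds named here, no step between measured compounds that differ in one place is available to guide the next comparison. Compound 3 `Cc1ccccc1SC(=S)N1CCN(C(=O)OC(C)(C)C)CC1` keeps the rest of compound 2 and carries 2-methylphenyl in place of 4-fluorophenyl on a sulfur. Going by the values given here, with no measured precedent for this exchange, only a modest rise in the number is expected in this assay, towards weaker inhibition and possibly no larger than the scatter. The estimated change is a 1.5-fold higher number from compound 2 to compound 3 (0.17 log units; within the scatter). The expected value for compound 3 is 2300 nM, with an estimated range from 800 nM to 6500 nM.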

Compound 3, half-maximal inhibitory concentration: 2270 nM
The estimate for compound 3 lay 1.0-fold (0.01 log units) above the measured number, and the stated range covers the measured number.
By their numbers in this assay, from the lowest: compounds 2 and 3 (each within the scatter of the next); then compound 1.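

In this assay, placing 2-methylphenyl where 4-fluorophenyl stood, on the sulfur whose other neighbour is the thiocarbonyl carbon, gives a 1.5-fold higher number from compound 2 to compound 3 (0.16 log units; within the scatter). Among the compounds shown here, this is the first single-place step, and it shows that these two groups, which have the same count of heavy atoms, cannot be told apart at this position in this read-out. No measurement bears on why the two groups read alike.

The compounds shown leave open whether the position tolerates a group of a different kind, such as a pyridine ring, a benzyl group or a phenyl ring carrying a carboxylic acid. They also leave open how plain phenyl would read on the core of compound 2, as compound 1 differs from it in more than one place.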